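A few compounds are considered here, and "the series" means these few. Any claim that something is new, unique, unknown or untested is made for them only; others in the source may bear on it.

Two compounds share one core. Compound 1 `CC1CCN(c2c(S(=O)(=O)c3ccc(Cl)c(Cl)c3)cnc3cc(F)ccc23)CC1` and compound 2 `CC1CCN(c2c(S(=O)(=O)c3ccc(F)c(F)c3)cnc3cc(Cl)ccc23)CC1` differ only in which halogens they carry. In an assay on isolated protein for displacement of a labelled ligand from metabotropic glutamate receptor 5 (Homo sapiens), with a stated time of 60 min, tested at 1 uM (on this read-out higher numbers stand for more inhibition at the one concentration tested (going by the name of the read-out) and lower numbers for less inhibition), compound 1 gives 94% and compound 2 gives 90%, two numbers that lie within the scatter of each other, so neither stands apart from the other. Compound 3 `CC1CCN(c2c(S(=O)(=O)c3ccc(F)c(F)c3)cnc3cc(F)ccc23)CC1` differs from compound 2 by fluoro in place of chloro on an aromatic carbon. For the measured compounds named here, no measured pair shows this exact change, so its effect is unknown. The step from compound 2 to compound 3 is expected to be a number 1 percentage points lower from compound 2 to compound 3 (within the scatter), nothing beyond the scatter. Compound 3 is therefore estimated at 89%, within 75% to 98%.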

Compound 3, a percentage reported as inhibition, at one concentration (the size of the read-out at that concentration, not a potency): 94%
For compound 3 the middle estimate is 5 percentage points below the measured one, and the stated range covers the measured number.
By their numbers in this assay, from the lowest: compounds 2, 1 and 3 (each within the scatter of the next).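

In this assay fluoro in place of chloro on the aromatic carbon gives a number 4 percentage points higher from compound 2 to compound 3 (within the scatter) while 3,4-difluorophenyl in place of 3,4-dichlorophenyl on the sulfonyl sulfur gives no change at the digits printed from compound 1 to compound 3 (within the scatter) and so neither single swap moves the read-out beyond the scatter. Compounds 1 and 2 differ in two places, so only compound 3 lets each place be read alone. Nothing here gives a reason for these results. Going by these compounds, whether an amine or a methoxy group on that aromatic carbon would keep this inhibition remains open. A reading at one concentration also leaves any difference in potency among these compounds open.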